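A few compounds are considered here, and "the series" means these few. Any claim that something is new, unique, unknown or untested is made for them only; others in the source may bear on it.

Compound 1 `CO[C@H]1CC[C@H]2CCN(C)[C@H]2C1` carries a methoxy group on its core. In an assay on HEK293 cells for displacement of a labelled ligand from Neuronal acetylcholine receptor; alpha4/beta4 (Rattus norvegicus), with a stated time of 4 h (a higher number here means a weaker inhibitor, a lower number a stronger inhibitor), compound 1 gives only a limit, > 300000 nM, which means the assay reports no actual number for it. Compound 2 `COCCO[C@H]1CC=C2CCN(C)[C@H]2C1` shows the same picture, because in this assay compound 2 also returns a limit, > 300000 nM. Both results sit at the limit of > 300000 nM in this assay, at which 2 of the 2 values shown sit, so among the measured compounds there is nothing that tells a weaker binder from a stronger one. Compound 3 `CN1CC[C@@H]2CC[C@H](O)C[C@@H]21` differs from compound 1 by hydrogen in place of methyl on an oxygen on a saturated carbon, in words hydrogen in place of methyl on an oxygen on a saturated carbon. Within the data shown here, no measured pair shows a step of this kind, so its size cannot be read from the data. The expected step of a number no higher from compound 1 to compound 3 (the limit leaves the size open) is none beyond the scatter, with the value most likely staying at the limit. Compound 3 is therefore estimated to give about 300000 nM in this assay, within a range from 50000 nM to 1500000 nM.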

Compound 3, inhibition constant: > 300000 nM
Compound 3 gave a limit, no number (the forecaster's own chance of this, stated with the estimate: 80%); the middle value lies on the limit itself.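

In this assay compound 3 gives only a limit (> 300000 nM), so the step from methoxy to hydroxy between compound 1 and compound 3 cannot be read: the limit of > 300000 nM in this assay, at which 3 of the 3 values shown sit. The compounds shown leave open whether any change on the shared core gives an actual number in this assay.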